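The compounds below may be only part of what the source reports. "The series", "measured", "known", "first", "only" and "open" are said of these compounds alone.

Working notes on the series. In a functional assay on MCF7 cells (Homo sapiens) for inhibition, read by MTT assay, with a stated time of 48 h (a higher number here means a weaker inhibitor, a lower number a stronger inhibitor), compound 1, `COc1cc(N(Cc2nc3ccccc3[nH]2)S(=O)(=O)c2ccc(C)cc2)cc(OC)c1OC`, gives 5400 nM. Compound 2, `COc1ccc(N(Cc2nc3ccccc3[nH]2)S(=O)(=O)c2ccc(C)cc2)cc1`, reaches only the limit of this assay, reported as > 50000 nM; this is a limit, not a number. Going by the values given here, the two values shown thus span from a measured number for compound 1 down to the limit of > 50000 nM in this assay, at which 1 of the 2 values shown sits, for compound 2, and no step between the two can be counted, as they differ in more than one place.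

Compound 3, `COc1ccc(N(Cc2nc3ccccc3[nH]2)S(=O)(=O)c2ccc(C)cc2)cc1OC`, has not yet been measured. It differs from compound 2 in one place: methoxy in place of hydrogen on an aromatic carbon. Compound 1 carries three methoxy groups on that ring and compound 2 one; compound 3 sits between the two in that count, and the measured numbers of compound 1 and compound 2 set the outer bounds of what is reasonable to expect here.

The step from compound 2 to compound 3 is expected to go toward stronger inhibition, estimated as an at least 2.5-fold lower number from compound 2 to compound 3 (0.39 log units; beyond the scatter), which is beyond the usual scatter. In this assay compound 3 is therefore estimated at 20000 nM, with a range from 6000 nM to 60000 nM; a report of only a limit remains quite possible.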

Compound 3, half-maximal inhibitory concentration: > 50000 nM
Compound 3 gave a limit, no number; the forecaster's own chance of this, stated with the estimate: 40%; middle value at least 2.5-fold (0.39 log units) from the limit.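

Moving from 4-methoxyphenyl to 3,4-dimethoxyphenyl does not bring a measured number into view in this assay: compound 3 gives > 50000 nM, which is a limit and not a number. The step between compound 2 and compound 3 cannot be read, and any change from the added methoxy group remains hidden, because both values are limits: the limit of > 50000 nM in this assay, at which 2 of the 3 values shown sit.

What compound 3 adds is a comparison with compound 1 that differs in one place: hydrogen in place of methoxy on an aromatic carbon gives an at least 9.2-fold higher number from compound 1 to compound 3 (0.96 log units; beyond the scatter), and among the compounds shown, only the ring with three methoxy groups reaches a measured number.

The compounds shown leave open whether the count of methoxy groups or the place of the third one decides this difference, since no compound with three methoxy groups in another arrangement stands here. They also leave open whether a hydroxyl group, an amine or a fluorine atom on that aromatic carbon would give a measured number in this assay.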